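This account rests on a few compounds, and the source may have more. Where it says the series, first, only, none or still open, it means among the compounds named here.

Compound 1 `CCOc1cc([C@@H](Nc2ccc3cnccc3c2)C(=O)NS(=O)(=O)c2ccccc2)ccc1OC(C)C`: in an assay on isolated protein for inhibition of Trypsin (Homo sapiens) (a lower number here means a stronger inhibitor, a higher number a weaker inhibitor), compound 1 gives > 5000 nM, which is a limit of the assay and not a number.
Compound 2 `CCOc1cc(C(Nc2ccc3cnccc3c2)C(=O)NS(=O)(=O)c2ccccc2)ccc1OC(C)C`: compound 2 gives > 5000 nM, again a limit.
Compound 3 `CCOc1cc(C(Nc2ccc3c(N)nccc3c2)C(=O)NS(=O)(=O)c2cccc(C(N)=O)c2)ccc1OC(C)C`: compound 3 gives > 5000 nM, also a limit.

Compound 2 therefore stands at the limit of this assay, as do the other two measured compounds. The step that the two limits leave unreadable from compound 1 to compound 2 cannot be read in size because the limit of > 5000 nM in this assay, at which 3 of the 3 values shown sit, leaves no number on either side of it; the only structural point at which the pair differs is the fact that one of compounds 1 and 2 is drawn with a defined configuration and the other without, at the place where they differ. Compound 3 differs from compound 2 in two places, and its value, too, is a limit, so nothing about direction or size can be taken from that pair either.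

Compound 4 `CCOc1cc(C(Nc2ccc3cnccc3c2)C(=O)NS(=O)(=O)c2ccccc2S(C)(=O)=O)ccc1OC(C)C` differs from compound 2 by methylsulfonyl in place of hydrogen on an aromatic carbon. Among the compounds with values here, none of the measured compounds varies at this position, and the one measured step is unreadable, so there is no measured guide to how this change might act. What the measured values do show is that three compounds of this series all sit at the limit. Compound 4 is therefore expected to sit near the limit as well, and the step that the limit leaves unreadable from compound 2 to compound 4 is expected to be small. The estimate for compound 4 is 8000 nM, with a range from 2000 nM to 50000 nM.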

Compound 4, inhibition constant: > 5000 nM
Compound 4: a limit, no number; the forecaster's own chance of this, stated with the estimate: 80%; the middle value does not contradict the limit.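

In this assay compound 4 gives > 5000 nM, which is a limit and not a number. No size can be read for the change from compound 2 to compound 4, because neither compound has a number to compare: the limit of > 5000 nM in this assay, at which 4 of the 4 values shown sit.

The compounds shown leave open how strong any of them really is, and whether methylsulfonyl in place of hydrogen changes that at all.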